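This account rests on a few compounds, and the source may have more. Where it says the series, first, only, none or still open, it means among the compounds named here.

- Compound 1 `COc1cc2ncnc(Nc3ccc(NC(=O)c4ccccc4OC)cc3)c2cc1OC`: > 100000 nM
- Compound 2 `CCc1ccc(C(=O)Nc2ccc(Nc3ncnc4cc(OC)c(OC)cc34)cc2)cc1`: 72000 nM
- Compound 3 `COc1cc2ncnc(Nc3ccc(NC(=O)c4ccccc4Cl)cc3)c2cc1OC`: 26000 nM

These values come from a functional assay on HepG2 cells (Homo sapiens) for inhibition, read by MTT assay; on this read-out lower numbers stand for stronger inhibition and higher numbers for weaker inhibition. The entry for compound 1, > 100000 nM, is a limit of the assay and not a number. Compound 3, at 26000 nM, has the lowest value of the set, and its nearest neighbour is compound 2 at 72000 nM.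

The next compound to be measured is compound 4 `COc1cc2ncnc(Nc3ccc(NC(=O)c4ccc(Cl)cc4)cc3)c2cc1OC`. It has 4-chlorophenyl in place of 2-chlorophenyl on a carbonyl carbon. The two have the same atoms, joined differently.

Among the compounds with values here, no measured step makes this exact exchange, so the evidence is indirect. Two steps end at the 2-chlorophenyl of compound 3. The first, a 2.8-fold lower number from compound 2 to compound 3 (0.44 log units; beyond the scatter), is modest and replaces 4-ethylphenyl. The second, an at least 3.8-fold lower number from compound 1 to compound 3 (0.58 log units; beyond the scatter), is at least modest and puts chloro in place of methoxy. The remaining step, an at least 1.3-fold lower number from compound 1 to compound 2 (0.14 log units; that floor lies within the scatter), has a floor within the scatter. Compound 4 keeps the chloro but carries a 4-substituted phenyl like compound 2, whose value is 72000 nM. It could therefore land between compound 3 and compound 2, so only a small upward move is expected.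

The estimated change is a 1.3-fold higher number from compound 3 to compound 4 (0.13 log units; within the scatter), and a step beyond the scatter is not expected. For compound 4 the expected value is 35000 nM, with an estimated range from 13000 nM to 90000 nM.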

Compound 4, half-maximal inhibitory concentration: 28000 nM
Beside the measured number, compound 4's estimate is 1.3-fold (0.10 log units) above it; low and high end bracket the measured number.
By their numbers in this assay, from the lowest: compounds 3 and 4 (each within the scatter of the next); then compound 2. At a limit, above all of these: compound 1.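

Moving the chloro from the 2-chlorophenyl to the 4-chlorophenyl on the carbonyl carbon makes no readable difference in this assay (a 1.1-fold higher number from compound 3 to compound 4 (0.03 log units; within the scatter)), so for this pair the placement of the chloro on the phenyl does not register. With the same placement on the phenyl, the group itself does count, as chloro in place of ethyl gives a 2.6-fold lower number from compound 2 to compound 4 (0.41 log units; beyond the scatter) and shows that having a group at that place on the phenyl does not by itself set the number. Compound 1 stands at a limit and not a number, so the comparison with its 2-methoxyphenyl, an at least 3.5-fold lower number from compound 1 to compound 4 (0.55 log units; beyond the scatter), gives only a floor: the limit of > 100000 nM in this assay, at which 1 of the 4 values shown sits.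

Each phenyl shown carries a single group, which leaves open what bromo, a nitrile, an amine or a carboxylic acid would do at the same place. From the compounds shown here alone, it also stays open whether the two chloro placements would remain this close with a longer chain on the phenyl or with a change to the shared core.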